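A few compounds are considered here, and "the series" means these few. Any claim that something is new, unique, unknown or untested is made for them only; others in the source may bear on it.

Of the compounds shown here, three built on one shared core have been tested for cytotoxicity in an ADME assay on BCBL1 cells (Homo sapiens) for cytotoxicity, with a stated time of 7 days; a lower number here means that less compound is tolerated, a higher number that more compound is tolerated. Compound 1 `CC(C)CSc1nc(N)nc2c1ncn2/C=C1/CC1(CO)CO` carries an isobutylsulfanyl group on the core. In this assay compound 1 reaches only a limit, > 20000 nM. Compound 2 `COCCOc1nc(N)nc2c1ncn2/C=C1/CC1(CO)CO` carries 2-methoxyethoxy in place of isobutylsulfanyl on an aromatic carbon. In this assay compound 2 likewise reaches only a limit, > 20000 nM. Compound 3 `CSc1nc(N)nc2c1ncn2/C=C1/CC1(CO)CO` has hydrogen in place of isopropyl on a saturated chain carbon bound to a sulfur, leaving a methylsulfanyl group. In this assay compound 3 also reaches only a limit, > 20000 nM. Every step among these three, namely a step that the two limits leave unreadable from compound 1 to compound 2, a step that the two limits leave unreadable from compound 1 to compound 3 and a step that the two limits leave unreadable from compound 2 to compound 3, is therefore unreadable, because of the limit of > 20000 nM in this assay, at which 3 of the 3 values shown sit.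

Compound 4 `Nc1nc(OCc2ccccc2)c2ncn(/C=C3/CC3(CO)CO)c2n1` has not yet been measured. It differs from compound 3 in this way: benzyloxy in place of methylsulfanyl on an aromatic carbon. Among the compounds with values here, none of the measured steps gives a readable size, so no direction can be drawn from them for compound 4; the only guide is that the three measured compounds all sit at the same limit. The expectation for compound 4 in this assay is therefore 30000 nM, within a range from 10000 nM to 100000 nM, most likely again reported as a limit. The step this estimate means is a step that the limit leaves unreadable from compound 3 to compound 4, expected to be unreadable as well.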

Compound 4, half-maximal cytotoxic concentration: > 20000 nM
Compound 4 ended at the assay's limit; the forecaster's own chance of this, stated with the estimate: 80%; the middle value lies beyond the limit too.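

Within the data shown here, compound 4 sits at a limit, as do compound 1, compound 2 and compound 3, so no step from compound 4 to any of the others can be read, because none of the four gives an actual number: the limit of > 20000 nM in this assay, at which 4 of the 4 values shown sit. In this assay, the compounds shown leave open at what concentration any of the four becomes cytotoxic, and whether changing the group on the shared core alters that concentration.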